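The compounds below may be only part of what the source reports. "The series", "measured", "known", "first", "only" and "open" are said of these compounds alone.

Compound 1 `Cc1cc(Nc2cc(-c3ccccc3)[nH]n2)n2nc(SCc3ccc([N+](=O)[O-])cc3)nc2n1`: 7980 nM
Compound 2 `Cc1cc(Nc2cc(-c3ccccc3)[nH]n2)n2nc(SCc3cccc4ccccc34)nc2n1`: 3950 nM

In a functional assay on PC-9 cells (Homo sapiens) for inhibition, read by MTT assay, with a stated time of 72 h (on this read-out higher numbers stand for weaker inhibition and lower numbers for stronger inhibition), compound 2 gives the lowest of the two numbers; compound 1 sits at 7980 nM, and the step of a 2.0-fold lower number from compound 1 to compound 2 (0.31 log units; beyond the scatter) is the only measured one. Compound 3 `CCCSc1nc2nc(C)cc(Nc3cc(-c4ccccc4)[nH]n3)n2n1` differs from compound 2 by ethyl in place of naphthalen-1-yl on a saturated chain carbon bound to a sulfur. That single step swapped one aromatic group for another, so it bears only loosely on removing both rings. A return toward the number of compound 1, or further, is expected: compound 3 is estimated at 9000 nM (range 3500 nM to 25000 nM), a step of a 2.3-fold higher number from compound 2 to compound 3 (0.36 log units; beyond the scatter).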

Compound 3, half-maximal inhibitory concentration: > 50000 nM
Compound 3 ended at the assay's limit (the forecaster's own chance of this, stated with the estimate: 10%); middle value at least 5.5-fold (0.74 log units) from the limit.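

Ethyl in place of naphthalen-1-yl (an at least 12-fold higher number from compound 2 to compound 3 (1.10 log units; beyond the scatter)) and ethyl in place of 4-nitrophenyl (an at least 6.2-fold higher number from compound 1 to compound 3 (0.79 log units; beyond the scatter)) both weigh far more in this assay than the exchange of one aromatic group for the other did. Compound 3 gives > 50000 nM as a limit of the assay and not as a number, so both steps are bounds only. Among these three compounds, then, the group on the saturated chain carbon bound to a sulfur matters strongly, and only the two aromatic groups give a measured number. As far as these compounds go, whether a ring itself is needed remains open. A cyclohexyl group or a longer chain such as octyl could separate the presence of a ring from the size of the group.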